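Working notes: from compound 3 to compound 4

This account rests on a few compounds, and the source may have more. Where it says the series, first, only, none or still open, it means among the compounds named here.

In an ADME assay on L02 cells (Homo sapiens) for inhibition, read by CCK-8 assay, with a stated time of 48 h (on this read-out lower numbers stand for stronger inhibition of growth and higher numbers for weaker inhibition of growth), compound 3 (`CN1CCN(c2ccc(Nc3ncc(Cl)c(NCc4ccc(C(F)(F)F)cc4)n3)nc2)CC1`) gives 26200 nM and compound 1 (`Cc1ccccc1Nc1nc(Nc2cccnc2)ncc1Cl`) gives 22900 nM, two values within the scatter of each other. Compound 3 therefore stands together with compound 1 on the numbers available. Compound 2 (`Cc1ccccc1Nc1nc(NC2CCCCC2)ncc1Cl`) reads > 100000 nM in this assay, and this is a limit of the assay, not a number.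

Compound 4 (`COc1ccccc1CNc1nc(Nc2ccc(N3CCN(C)CC3)cn2)ncc1Cl`) carries 2-methoxyphenyl in place of 4-(trifluoromethyl)phenyl on a saturated chain carbon bound to a nitrogen on an aromatic ring.

Among the compounds with values here, the only measured step (an at least 4.3-fold higher number from compound 1 to compound 2 (0.64 log units; beyond the scatter)) is cyclohexyl in place of pyridin-3-yl on a nitrogen on an aromatic ring. That is a different change at a different place, so it bears on the present change only weakly. Within the data shown here, no measured step alters the group on the saturated chain carbon. No shift beyond the scatter is therefore expected in this assay, and no direction can be favoured. The expected move is small (a 1.1-fold higher number from compound 3 to compound 4 (0.06 log units; within the scatter)) on this estimate. Compound 4 is estimated at 30000 nM, with an expected range from 12000 nM to 80000 nM in this read-out.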

Compound 4, concentration for 50% growth inhibition: 25500 nM
Estimate against measurement, compound 4: 1.2-fold (0.07 log units) above; the measured number falls inside the stated range.
By their numbers in this assay, from the lowest: compounds 1, 4 and 3 (each within the scatter of the next). At a limit, above all of these: compound 2.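

In this assay, the exchange of 4-(trifluoromethyl)phenyl for 2-methoxyphenyl on a saturated chain carbon bound to a nitrogen on an aromatic ring reads a 1.0-fold lower number from compound 3 to compound 4 (0.01 log units; within the scatter). Within the data shown here, this is the first reading at this place, and it puts the two groups level on this read-out, although the entering group brings an oxygen and a hydrogen-bond acceptor and the leaving group takes three fluorine atoms with it. Nothing shown gives a cause for this result.

One pair of groups cannot show how far this tolerance extends across other groups at this place. Going by these compounds, what an amine or a carboxylic acid on the phenyl ring, or a longer chain in place of the benzyl group, would do to this read-out stays open.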